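A few compounds are considered here, and "the series" means these few. Any claim that something is new, unique, unknown or untested is made for them only; others in the source may bear on it.

In a functional assay on MDA-N cells (Homo sapiens) (on this read-out higher numbers stand for weaker inhibition of growth and lower numbers for stronger inhibition of growth), compound 1 (`COc1cccc(-c2cc(O)c3c(C)cc(C)nc3n2)c1`) gives < 10 nM as its result, which is a limit of the assay and not a number. Compound 1 sits at the limit of < 10 nM in this assay, at which 1 of the 2 values shown sits, and so has no exact position in the series. Among the measured compounds shown here, compound 2 (`COc1ccc(-c2cc(O)c3cc(C)cnc3n2)cc1`) reads 1700 nM in this assay and differs from compound 1 in more than one place, so it offers no single-change step. Compound 3 (`COc1cccc(-c2cc(O)c3c(C)ccnc3n2)c1`) is still unmeasured and differs from compound 1 in one place (hydrogen in place of methyl on an aromatic carbon): hydrogen in place of methyl on an aromatic carbon, next to the ring nitrogen. For the measured compounds named here, no measured step bears on this change, so the expectation is loose. An estimated at least 2.5-fold higher number from compound 1 to compound 3 (0.39 log units; beyond the scatter) is expected, modest and toward weaker inhibition of growth, though a change within the scatter remains possible. For compound 3 the estimate is 25 nM with an expected range from 6 nM to 200 nM in this assay as a whole.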

Compound 3, concentration for 50% growth inhibition: < 10 nM
Compound 3 gave a limit, no number (the forecaster's own chance of this, stated with the estimate: 40%); at least 2.5-fold (0.39 log units) between middle value and limit.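

Among the compounds shown here, compound 1 and compound 3 both give a limit and not a number in this assay, so no step between them can be read: the limit of < 10 nM in this assay, at which 2 of the 3 values shown sit.

The compounds shown leave open how much, if at all, hydrogen in place of methyl on an aromatic carbon changes the result in this assay.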